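The source may report more compounds than this note shows. Statements on the series, on what has been measured and on what is new or still open speak of the compounds shown alone.

Compound 1 `CN(C)Cc1ccc(Nc2nnc(-c3cc(-c4cccnc4)cc(C(F)(F)F)c3)o2)cc1` gives 3.2 in a physicochemical assay for lipophilicity, at pH 7.4 (a higher number here means a more lipophilic compound, a lower number a more polar compound), the lower of the two numbers measured, while compound 2 `FC(F)(F)c1cc(-c2cccnc2)cc(-c2nnc(Nc3ccc(CN4CCCC4)cc3)o2)c1` gives 3.3; the change a number 0.10 log units higher from compound 1 to compound 2 (within the scatter) lies within the scatter. Compound 3 `CN(C)Cc1ccc(Nc2nnc(-c3cc(-c4cccnc4)cc(C(F)(F)F)c3)o2)cn1` differs from compound 1 by 6-((dimethylamino)methyl)pyridin-3-yl in place of 4-((dimethylamino)methyl)phenyl on a nitrogen on an aromatic ring. Within the data shown here, no measured step touches this kind of exchange, so the single step from compound 1 to compound 2 says nothing about it. The added ring nitrogen is expected to lower the number, so compound 3 is expected to give 2.2, between 1.5 and 2.9, a drop of a number 1.00 log units lower from compound 1 to compound 3 (beyond the scatter).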

Compound 3, distribution coefficient: 2.9
Estimate against measurement, compound 3: 0.70 log units below; low and high end bracket the measured number.
By their numbers in this assay, from the lowest: compounds 3, 1 and 2 (each within the scatter of the next, the first and the last beyond it).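

Among these compounds, with 6-((dimethylamino)methyl)pyridin-3-yl in place of 4-((dimethylamino)methyl)phenyl on a nitrogen on an aromatic ring, this assay gives a number 0.30 log units lower from compound 1 to compound 3 (within the scatter) as the only reading of this exchange. The two compounds therefore cannot be told apart in this measurement, so this exchange of aromatic rings on the shared core, like the earlier exchange of amines, gives no step beyond the scatter. Nothing at hand bears on the reason for this result. The compounds shown leave open whether the same ring exchange would read alike with pyrrolidin-1-yl as the amine, and how a pyrimidine ring or a morpholine would read in this place.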